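A Nitro Group in Place of Methoxy on the Benzamide

A few compounds are considered here, and "the series" means these few. Any claim that something is new, unique, unknown or untested is made for them only; others in the source may bear on it.

Measured compounds in a functional assay on GTL 16 cells for antiproliferative activity against GTL 16 cell line (Homo sapiens), read by CCK-8 assay, with a stated time of 72 h; a higher number here means a weaker inhibitor, a lower number a stronger inhibitor:
compound 1 `COc1ccc(C(=O)Nc2cccc(-c3oc4cc(-c5ccc(F)cc5)ccc4c(=O)c3O)c2)cc1` gives 21100 nM
compound 2 `O=C(Nc1cccc(-c2oc3cc(-c4ccc(F)cc4)ccc3c(=O)c2O)c1)c1ccc(Cl)cc1` gives 9140 nM
compound 3 `Cc1ccccc1C(=O)Nc1cccc(-c2oc3cc(-c4ccc(F)cc4)ccc3c(=O)c2O)c1` gives 24800 nM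

Compound 1 stands second highest of the three numbers in this assay; compound 3 sits within the scatter of it, while compound 2 is clearly lower. Compound 4 `O=C(Nc1cccc(-c2oc3cc(-c4ccc(F)cc4)ccc3c(=O)c2O)c1)c1ccc([N+](=O)[O-])cc1` differs from compound 1 by a single change: nitro in place of methoxy on an aromatic carbon. For the measured compounds named here, the one measured step that bears on a change at this same place is a 2.3-fold lower number from compound 1 to compound 2 (0.36 log units; beyond the scatter), a modest lowering. The step of a 2.7-fold higher number from compound 2 to compound 3 (0.43 log units; beyond the scatter) shows the other direction when that 4-chlorophenyl is replaced, but it does not involve the same position. On this basis a modest lowering of similar size is expected for compound 4, a 1.8-fold lower number from compound 1 to compound 4 (0.25 log units; within the scatter). The expected value for compound 4 in this assay is 12000 nM, with a range of 5000 nM to 30000 nM.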

Compound 4, half-maximal inhibitory concentration: 18200 nM
The estimate for compound 4 lay 1.5-fold (0.18 log units) below the measured number; measured number inside the range.
By their numbers in this assay, from the lowest: compounds 2, 4, 1 and 3 (each within the scatter of the next, the first and the last beyond it).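

At this aromatic carbon, nitro does not separate from methoxy in this assay (a 1.2-fold lower number from compound 1 to compound 4 (0.06 log units; within the scatter)). Compound 4 also lies within the scatter of the 2-methylphenyl amide (a 1.4-fold lower number from compound 3 to compound 4 (0.13 log units; within the scatter)) and of the chloro compound (a 2.0-fold higher number from compound 2 to compound 4 (0.30 log units; within the scatter)), so it overlaps both, even though those two lie apart from each other. No measurement available here accounts for this result. The compounds shown leave open whether an amine, a carboxylic acid or a longer chain at this place would move the number beyond the scatter of compound 1.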